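The source may report more compounds than this note shows. Statements on the series, on what has been measured and on what is new or still open speak of the compounds shown alone.

Of the compounds shown here, three have been measured in a functional assay on SMMC-7721 cells (Homo sapiens) for inhibition, read by CCK-8 assay, with a stated time of 72 h, tested at 8 uM; a lower number here means less inhibition of growth, a higher number more inhibition of growth at the concentration tested. Compound 1 (`COc1ccc(SCc2ccc(/C=C/C(=O)Nc3ccccc3N)cc2)cc1OC`) gives 44.6%, compound 3 (`COC(=O)c1ccccc1SCc1ccc(C(=O)Nc2ccccc2N)cc1`) gives 62.5%, and compound 2 (`COc1ccc(SCc2ccc(C(=O)Nc3ccccc3N)cc2)cc1`) gives 80.1%. Compound 2 therefore stands highest of the three, and its distance to each of the other two lies beyond the scatter.

The next compound is compound 4 (`Nc1ccccc1NC(=O)c1ccc(CSc2ccc(F)cc2)cc1`), which departs from compound 2 in a single place: fluoro in place of methoxy on an aromatic carbon. Put another way, the 4-methoxyphenyl group of compound 2 becomes a 4-fluorophenyl group.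

Among the measured compounds shown here, no two measured compounds differ in one place only, so the data offer no direct precedent for this exchange in this assay. Without the 4-methoxyphenyl group of compound 2, compound 3 still reaches 62.5%, so substantial growth inhibition is expected to survive the exchange. Compound 2 also holds the top value of a very small set, which makes a modest fall more likely than a rise. The expected change is a number 10.1 percentage points lower from compound 2 to compound 4 (beyond the scatter), a step that may not clear the scatter. For compound 4 the estimated value is 70%, with an expected range from 50% to 88%.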

Compound 4, percent growth inhibition at one concentration: 81.9%
Compound 4: middle estimate off by 11.9 percentage points, on the low side; the measured number falls inside the stated range.
By their numbers in this assay, from the lowest: compound 1; then compound 3; then compounds 2 and 4 (each within the scatter of the next).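

In this assay, among the compounds shown here, the exchange of methoxy for fluoro on an aromatic carbon para to a large group amounts to a number 1.8 percentage points higher from compound 2 to compound 4 (within the scatter), and this is the first step that compares two compounds differing in one place only. The 4-methoxyphenyl group of compound 2 and the 4-fluorophenyl group of compound 4 therefore cannot be told apart at the concentration tested, even though the entering fluoro group has one heavy atom where methoxy has two, and no hydrogen-bond acceptor where methoxy has one. No measurement at hand bears on the reason the two compounds read alike, so the result stands here as an observation only.

Still open, from the compounds shown here alone, is how a plain hydrogen at this position, or an amine, a carboxylic acid or a longer alkoxy chain, would read against compound 2 and compound 4. Also open, going by these compounds, is whether the same exchange would read alike on the core of compound 1, and whether compound 2 and compound 4 would remain indistinguishable at concentrations other than the single one tested.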